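Replacing a Carbamoylphenyl Amide with a Methylsulfonylphenyl Amide

The compounds below may be only part of what the source reports. "The series", "measured", "known", "first", "only" and "open" are said of these compounds alone.

The series builds on compound 1 `NC(=O)c1cccc(C(=O)N2CCC(N(C3CC3)S(=O)(=O)c3cccc(C(F)(F)F)c3)CC2)c1`, a cyclopropyl sulfonamide carrying a trifluoromethylphenyl group on the sulfonyl and an aromatic amide on the ring nitrogen. In an assay on cells for inhibition of Voltage-dependent L-type calcium channel subunit alpha-1C (Homo sapiens), read by FLIPR and calcium flux, tested at 3 uM (on this read-out higher numbers stand for a stronger effect at the one concentration tested and lower numbers for a weaker effect), compound 1 stands as "not determined" (no result reported), so no single number is available for it. Its close relative compound 2 `NC(=O)c1ccc(C(=O)N2CCC(N(C3CC3)S(=O)(=O)c3cccc(C(F)(F)F)c3)CC2)cc1` has been run, and in this assay compound 2 gives 0%, so within this small set the only measured point shows no effect at the concentration tested.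

Compound 3 `CS(=O)(=O)c1ccccc1C(=O)N1CCC(N(C2CC2)S(=O)(=O)c2cccc(C(F)(F)F)c2)CC1` follows from compound 1 through a single exchange: 2-(methylsulfonyl)phenyl in place of 3-carbamoylphenyl on a carbonyl carbon. The change keeps the shared core and the cyclopropyl sulfonamide intact and alters only the aromatic amide. No comparison between two measured compounds is available here, so the size of the step from compound 1 to compound 3 in this assay cannot be anchored to an observed precedent; given that compound 2 gives 0%, a step no larger than the usual scatter, in either direction, is expected. On that basis compound 3 is expected to give about 5% in this assay, estimated within the range -10% to 25%.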

Compound 3, a percentage reported as inhibition, at one concentration (the size of the read-out at that concentration, not a potency): 39%
Compound 3: the middle estimate sits 34 percentage points below what was measured, and the stated range ends below it.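

In this assay the exchange of 4-carbamoylphenyl for 2-(methylsulfonyl)phenyl on a carbonyl carbon gives a number 39 percentage points higher from compound 2 to compound 3 (beyond the scatter) and leaves the rest of the molecule unchanged. Compound 2 alone had shown no effect at the one concentration tested, whereas compound 3 shows that this place on the amide can change the read-out and that a compound of this series can register inhibition, although that figure is the size of a read-out and not a potency. The step from compound 1 cannot be read, since compound 1 has no number, and nothing measured here accounts for the gain.

The pair changes two things at once, the group and its numbered place on the phenyl ring, so the compounds shown do not tell whether the methylsulfonyl group or that place carries the step. They also leave open whether a nitrile, a carboxylic acid or a longer chain such as ethylsulfonyl on the phenyl ring would keep the read-out of compound 3.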